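From Pyrazolyl to Trifluoromethylphenyl on a Shared Core

The source may hold more compounds than are shown below. What is called first, only, known or untested is meant among the compounds shown, and "the series" means these compounds.

In a functional assay on NCI-H1993 cells (Homo sapiens) for inhibition, read by CCK-8 assay, with a stated time of 72 h (on this read-out higher numbers stand for weaker inhibition and lower numbers for stronger inhibition), compound 1 (`CC(c1c(F)cc2ncccc2c1F)n1cnc2ncc(-c3ccncc3)nc21`) gives 162 nM. Compound 2 (`c1cnc2ccc(Cn3cnc4ncc(-c5cn[nH]c5)nc43)cc2c1`) gives 2890 nM, the higher of the two numbers by a gap beyond the scatter, which makes it the weaker inhibitor of this pair. Compound 3 (`FC(F)(F)c1ccc(-c2cnc3ncn(Cc4ccc5ncccc5c4)c3n2)cc1`) comes from compound 2 by a single exchange on an aromatic carbon, with 4-(trifluoromethyl)phenyl in place of 1H-pyrazol-4-yl on an aromatic carbon. Going by the values given here, no measured pair of compounds isolates this exchange, and compound 1 and compound 2 differ in more than one place, so the data set no firm direction. In this assay, the expected change, a 1.4-fold higher number from compound 2 to compound 3 (0.14 log units; within the scatter), is no step beyond the scatter, though with wide uncertainty. Compound 3 is estimated at 4000 nM, with an expected range from 1000 nM to 15000 nM.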

Compound 3, half-maximal inhibitory concentration: > 10000 nM
Compound 3: no number, only a limit; the forecaster's own chance of this, stated with the estimate: 20%; at least 2.5-fold (0.39 log units) between middle value and limit.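

The exchange of 1H-pyrazol-4-yl for 4-(trifluoromethyl)phenyl on an aromatic carbon of the shared core gives an at least 3.4-fold higher number from compound 2 to compound 3 (0.53 log units; beyond the scatter), which means weaker inhibition. Going by these compounds alone, this is the first step that isolates a single change at this position, something compound 1 and compound 2 could not do, as they differ in more than one place, and it shows that the group held here can move the read-out beyond the scatter. Compound 3 gives only a limit in this assay, not a number: the limit of > 10000 nM in this assay, at which 1 of the 3 values shown sits.

Going by these compounds, how far the true value of compound 3 lies from that limit remains open. Also open, on these data alone, is whether the loss belongs to the phenyl ring or to its trifluoromethyl, and how a plain phenyl, or a phenyl carrying an amine or a carboxylic acid, would read at this position.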